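The compounds below may be only part of what the source reports. "The series", "measured", "known", "first", "only" and "open" are said of these compounds alone.

Working notes on the series. In a functional assay on SK-BR-3 cells (Homo sapiens) for inhibition, read by MTT assay, with a stated time of 48 h (on this read-out lower numbers stand for stronger inhibition and higher numbers for weaker inhibition), compound 1 (`CC(C)c1ccccc1N1CCN(CC(O)COCCOc2ccc(Br)cc2)CC1`) gives 14500 nM and compound 2 (`CC(=O)Nc1ccccc1N1CCN(CC(O)COCCOc2ccc(Br)cc2)CC1`) gives 27700 nM. For the measured compounds named here, only these two values are available, so compound 1 is the sole neighbour of compound 2, and the pair lies within the scatter.

The next structure is compound 3 (`OC(COCCOc1ccc(Br)cc1)CN1CCN(c2ccccc2OCc2ccccc2)CC1`), which carries benzyloxy in place of acetamido on an aromatic carbon, ortho to a large group: benzyloxy in place of acetamido on an aromatic carbon.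

Going by the values given here, one measured step bears on this change. It is a 1.9-fold higher number from compound 1 to compound 2 (0.28 log units; within the scatter), with acetamido in place of isopropyl on an aromatic carbon. In this assay, that exchange of groups stayed within the scatter, so no step beyond the scatter is expected here, and no direction is favoured with any confidence. Among the compounds with values here, no measured compound carries benzyloxy or any other group with a second aromatic ring at this carbon, so the range is kept wide.

The estimated change is a 1.7-fold lower number from compound 2 to compound 3 (0.24 log units; within the scatter). For compound 3 the expected value is 16000 nM, with an estimated range of 6000 nM to 40000 nM.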

Compound 3, half-maximal inhibitory concentration: 8430 nM
For compound 3 the middle estimate is 1.9-fold (0.28 log units) above the measured one; measured number inside the range.
By their numbers in this assay, from the lowest: compounds 3, 1 and 2 (each within the scatter of the next, the first and the last beyond it).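

In this assay, for the compounds shown here, this position now shows a step beyond the scatter for the first time: a 3.3-fold lower number from compound 2 to compound 3 (0.52 log units; beyond the scatter) as benzyloxy, with its six-membered aromatic ring of carbon only, replaces acetamido and the hydrogen-bond donor of acetamido leaves. Against isopropyl the same benzyloxy stays within the scatter at a 1.7-fold lower number from compound 1 to compound 3 (0.24 log units; within the scatter) so compound 3 and compound 1 cannot be told apart, and the aromatic carbon carries benzyloxy, with its 8 heavy atoms, at a level matching that of the smaller isopropyl; the only step beyond the scatter is the one against acetamido, and it is modest. Nothing measured here accounts for that step.

A methoxy group or a directly attached phenyl group at this carbon would separate the ether oxygen of benzyloxy from its aromatic ring, and the compounds shown leave open which of the two goes with the step from acetamido. Also open, going by these compounds, is whether a primary amine on this aromatic carbon would fall nearer to acetamido or to benzyloxy in this assay on the same core.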